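This account rests on a few compounds, and the source may have more. Where it says the series, first, only, none or still open, it means among the compounds named here.

Compound 3 `CN(C)CCCNc1nc(N)nc2cc(-c3ccc(C(F)(F)F)cc3)sc12` carries a (3-(dimethylamino)propyl)amino group and an amino group on the shared core. Among the compounds with values here, in a physicochemical assay for solubility, at pH 2 (on this read-out lower numbers stand for lower solubility and higher numbers for higher solubility), compound 3 gives 210 ug/mL, the only outright number among the three measured compounds. Compound 1 `CNc1nc(N2CCC(N)CC2)c2sc(-c3ccc(C(F)(F)F)cc3)cc2n1` reaches only a limit of this assay, > 200 ug/mL. Compound 2 `CNc1nc(NC2CCOCC2)c2sc(-c3ccc(C(F)(F)F)cc3)cc2n1` likewise reaches only a limit, < 5 ug/mL. Within the data shown here, the one step between measured compounds is an at least 40-fold lower number from compound 1 to compound 2 (1.60 log units; beyond the scatter); both of its ends sit at a limit, the limit of > 200 ug/mL in this assay, at which 1 of the 3 values shown sits, and (the limit of < 5 ug/mL in this assay, at which 1 of the 3 values shown sits).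

Compound 4 `CN(C)CCCNc1ncnc2cc(-c3ccc(C(F)(F)F)cc3)sc12` differs from compound 3 in one place: hydrogen in place of amino on an aromatic carbon. Among the measured compounds shown here, no measured step removes this amino group; the step from compound 1 to compound 2 exchanged one whole ring substituent for a different one and is only a loose guide. Compound 4 keeps the (3-(dimethylamino)propyl)amino group intact, and because compound 3 already gives 210 ug/mL with that group in place, the expected step of a 1.4-fold lower number from compound 3 to compound 4 (0.15 log units; within the scatter) is estimated to be small, at most a modest decrease that may not exceed the usual scatter. For compound 4 the estimate in this assay is 150 ug/mL, with a range from 50 ug/mL to 300 ug/mL.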

Compound 4, solubility: 209 ug/mL
The estimate for compound 4 lay 1.4-fold (0.14 log units) below the measured number, and the stated range covers the measured number.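

Exchanging the amino group for hydrogen on the aromatic carbon between two ring nitrogen atoms gives, in this assay, a 1.0-fold lower number from compound 3 to compound 4 (0.00 log units; within the scatter). At this place, then, with the (3-(dimethylamino)propyl)amino group kept, the read-out is the same with or without the amino group, as far as the usual scatter of repeated measurements can tell. The earlier step could not show this: it exchanged a different substituent and both of its ends were limits, whereas this step joins two outright numbers, and nothing measured here gives a reason for the absence of a difference.

On these data alone, what remains open is whether a different small group at this place, such as a methyl group, a hydroxyl group or a carboxylic acid, would also leave the number unchanged. Also open, as far as these compounds go, is whether the amino group would matter just as little if the (3-(dimethylamino)propyl)amino group gave way to a chain ending in an alcohol rather than an amine, or to a longer chain with the same dimethylamino end.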